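The source may report more compounds than this note shows. Statements on the series, on what has been measured and on what is new or still open speak of the compounds shown alone.

Measured compounds:
Compound 1 `CCOC(=O)CCN(c1ccccc1)[C@H]1c2cc(C#N)ccc2OC(C)(C)[C@@H]1O` in a functional assay (aorta) with Rattus norvegicus as the target; on this read-out higher numbers stand for weaker inhibition and lower numbers for stronger inhibition: 54000 nM.
Compound 2 `CCOC(=O)CN(c1ccc(F)cc1)[C@H]1c2cc(C#N)ccc2OC(C)(C)[C@@H]1O` in this assay: > 30000 nM, a limit of the assay rather than a number.

Compound 1 holds the only number shown. The value of compound 2 is a limit, as the limit of > 30000 nM in this assay, at which 1 of the 2 values shown sits, records. For the measured compounds named here, no step between measured compounds is available. Compound 3 `Cc1noc(CN(c2ccccc2)[C@H]2c3cc(C#N)ccc3OC(C)(C)[C@@H]2O)n1` differs from compound 1 by 3-methyl-1,2,4-oxadiazol-5-yl in place of (ethoxycarbonyl)methyl on a saturated chain carbon bound to a nitrogen on an aromatic ring. Going by the values given here, no measured pair tells the size of such a change, so in this assay a step within the usual scatter is expected, a 1.4-fold lower number from compound 1 to compound 3 (0.13 log units; within the scatter). Compound 3 is therefore estimated at 40000 nM, with a range from 10000 nM to 150000 nM.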

Compound 3, half-maximal inhibitory concentration: > 30000 nM
Compound 3: only a limit was reported (the forecaster's own chance of this, stated with the estimate: 40%); the middle value is on the limit's open side.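

For the compounds shown here, the result for compound 3 is only a limit, so no step from compound 1 to compound 3 can be read. The compounds shown leave open what size of change 3-methyl-1,2,4-oxadiazol-5-yl in place of (ethoxycarbonyl)methyl brings in this assay.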